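A few compounds are considered here, and "the series" means these few. Any claim that something is new, unique, unknown or untested is made for them only; others in the source may bear on it.

Measured compounds in an ADME assay on HCT-116 cells (Homo sapiens) for cytotoxicity, read by CellTiter-Glo, with a stated time of 72 h; on this read-out lower numbers stand for stronger inhibition and higher numbers for weaker inhibition:
compound 1 `Cc1cc(C)c(S(=O)(=O)N2CCN(C3CN4CCC3CC4)CC2)c(C)c1` gives > 5000 nM, which is a limit of the assay and not a number.
compound 2 `CCc1ccc(S(=O)(=O)N2CCC(N3CCC(C)CC3)CC2)cc1` gives > 5000 nM, again a limit of the assay.
compound 3 `CC1CCN(C2CCN(S(=O)(=O)c3ccccc3-c3ccccc3)CC2)CC1` gives > 5000 nM, again a limit of the assay.

On the numbers shown, compound 1 stands at the limit of > 5000 nM in this assay, at which 3 of the 3 values shown sit. Among the measured compounds shown here, no measured compound in this set has returned a number rather than a limit, so no step between measured compounds can be put into figures, and nothing on this read-out separates compound 1 from compound 2 or compound 3.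

Compound 4 `Cc1cc(C)c(S(=O)(=O)N2CCN(C3CCN(C)CC3)CC2)c(C)c1` follows from compound 1 by a single change: a group of 7 heavy atoms (6 carbon, 1 nitrogen; one six-membered non-aromatic ring with 1 hetero atom) in place of a group of 8 heavy atoms (7 carbon, 1 nitrogen; 2 six-membered non-aromatic rings with 1 hetero atom each), on an amine nitrogen in a ring. The shared core of compound 1, with its sulfonyl-linked aromatic part, is kept; only the group on the amine nitrogen in the ring is exchanged.

Because every measured value sits at the limit of > 5000 nM in this assay, at which 3 of the 3 values shown sit, a step that the limit leaves unreadable from compound 1 to compound 4 is expected, that is, none beyond the scatter. Compound 4 is estimated at 9000 nM, with a range from 3000 nM to 40000 nM, and this assay will most likely again report only a limit for compound 4.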

Compound 4, half-maximal inhibitory concentration: > 5000 nM
Compound 4: only a limit was reported; the forecaster's own chance of this, stated with the estimate: 85%; the middle value is on the limit's open side.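

No step can be read from compound 1 to compound 4, because both results are limits of the assay and not numbers: the limit of > 5000 nM in this assay, at which 4 of the 4 values shown sit.

The compounds shown leave open whether any group on the amine nitrogen in the ring would return a number rather than a limit on this read-out.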